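A few compounds are considered here, and "the series" means these few. Any claim that something is new, unique, unknown or untested is made for them only; others in the source may bear on it.

In a functional assay on HL-60 cells (Homo sapiens) for antiproliferative activity, read by sulforhodamine B assay, with a stated time of 72 h (on this read-out higher numbers stand for weaker inhibition and lower numbers for stronger inhibition), compound 1 `Fc1ccc(Nc2nncc3ccccc23)cc1` gives 6.4 nM and compound 2 `NS(=O)(=O)c1ccc(Nc2nncc3ccccc23)cc1` gives 18 nM as the higher of the two numbers. Compound 3 `N#Cc1ccc(Nc2nncc3ccccc23)cc1` carries cyano in place of sulfamoyl on an aromatic carbon, and the full count of that swap reads cyano in place of sulfamoyl on an aromatic carbon for comparison. For the measured compounds named here, only one measured step bears on this spot: a 2.8-fold higher number from compound 1 to compound 2 (0.45 log units; beyond the scatter) with sulfamoyl in place of fluoro, a modest move beyond the scatter. Taking sulfamoyl away may undo part of that step, so a modest drop is expected in this assay toward stronger inhibition. The estimated step is a 1.8-fold lower number from compound 2 to compound 3 (0.26 log units; within the scatter) for now. For compound 3 the estimate is 10 nM with 3.5 nM to 28 nM as its expected range.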

Compound 3, half-maximal inhibitory concentration: 5.5 nM
Estimate against measurement, compound 3: 1.8-fold (0.26 log units) above; the range from low to high includes it.
By their numbers in this assay, from the lowest: compounds 3 and 1 (each within the scatter of the next); then compound 2.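

Replacing sulfamoyl with cyano on this aromatic carbon gives a clear change (a 3.3-fold lower number from compound 2 to compound 3 (0.51 log units; beyond the scatter)), whereas cyano in place of fluoro does not move the number beyond the scatter (a 1.2-fold lower number from compound 1 to compound 3 (0.07 log units; within the scatter)). Among these three groups, fluoro and cyano therefore sit level, and only sulfamoyl stands apart, on the weaker side. No measurement shown here explains this difference. Still open, from the compounds shown here alone, is how an amine, a methoxy group or a carboxylic acid would behave at this position. Also open, going by these compounds, is whether sulfamoyl's weaker result would carry over to other cell lines.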